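Hydrogen for methyl on the compound 2 aryl ring

The compounds below may be only part of what the source reports. "The series", "measured", "known", "first", "only" and "open" are said of these compounds alone.

In an ADME assay on a cell-free system (plasma, Mus musculus) for metabolic stability, read by HPLC, with a stated time of 120 min, tested at 2 uM (on this read-out lower numbers stand for a shorter-lived compound and higher numbers for a longer-lived compound), compound 1 `O=C(NCCCCc1ccccc1)n1ncc2ccccc21` gives > 2 h, a limit of the assay. Compound 2 `Cc1ccc(CNC(=O)n2c(N)nc3ccccc32)cc1` gives < 0.0834 h, also a limit, and stands at the short-lived end of the two values. Compound 3 `Nc1nc2ccccc2n1C(=O)NCc1ccccc1` carries hydrogen in place of methyl on an aromatic carbon. Among the compounds with values here, no measured pair shows this change. With compound 2 at < 0.0834 h, compound 3 is expected to remain short-lived. The estimated step that the limit leaves unreadable from compound 2 to compound 3 is no larger than the scatter, with no direction expected. Compound 3 is estimated at 0.07 h, with an expected range of 0.03 h to 0.2 h.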

Compound 3, half-life: 0.217 h
Estimate against measurement, compound 3: 3.1-fold (0.49 log units) below; measured number above the stated range.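

In this assay, going from the 4-methylphenyl to the phenyl group gives an at least 2.6-fold higher number from compound 2 to compound 3 (0.41 log units; beyond the scatter), so the half-life of this pair responds to a single change on the aromatic carbon para to a large group. The true size of the step stays unknown, because compound 2 stands at a limit of the assay: the limit of < 0.0834 h in this assay, at which 1 of the 3 values shown sits.

Only methyl and hydrogen are shown at this place, so whether a methoxy group or a carboxylic acid there would give a longer or shorter half-life stays open. Compound 1 differs from compound 3 in more than one place and offers no comparison.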